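Chalcone series: hydroxy-methoxyphenyl in place of trimethoxyphenyl

The source may report more compounds than this note shows. Statements on the series, on what has been measured and on what is new or still open speak of the compounds shown alone.

Going by the values given here, compound 2 `COc1ccc(-c2cn(-c3cccc(C(=O)/C=C/c4cc(OC)c(OC)c(OC)c4)c3)c(=O)[nH]2)cc1` gives the lower of the two numbers so far in a functional assay on Malme-3M cells (Homo sapiens) for inhibition (on this read-out higher numbers stand for weaker inhibition of growth and lower numbers for stronger inhibition of growth), at 1790 nM. Compound 1 `COc1cc(/C=C/C(=O)c2cccc(-n3cc(-c4ccccc4)[nH]c3=O)c2)ccc1O` sits within the scatter of it, with 2670 nM in this assay. Compound 3 `COc1ccc(-c2cn(-c3cccc(C(=O)/C=C/c4ccc(O)c(OC)c4)c3)c(=O)[nH]2)cc1` is not yet measured; it carries 4-hydroxy-3-methoxyphenyl in place of 3,4,5-trimethoxyphenyl on a double-bonded chain carbon bound to a double-bonded chain carbon. Among the compounds with values here, no step between measured compounds is known for this change alone, since compound 1 and compound 2 differ in two places. The step from compound 2 to compound 3 is therefore expected to be none beyond the scatter, and compound 3 is estimated at 2500 nM in this assay, in the range 1200 nM to 5500 nM, which means a 1.4-fold higher number from compound 2 to compound 3 (0.15 log units; within the scatter).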

Compound 3, concentration for 50% growth inhibition: 4420 nM
For compound 3 the middle estimate is 1.8-fold (0.25 log units) below the measured one, within the range that was stated.
By their numbers in this assay, from the lowest: compounds 2, 1 and 3 (each within the scatter of the next, the first and the last beyond it).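

In this assay, going by these compounds alone, the 4-hydroxy-3-methoxyphenyl for 3,4,5-trimethoxyphenyl change on the double-bonded chain carbon gives a 2.5-fold higher number from compound 2 to compound 3 (0.39 log units; beyond the scatter), the first step beyond the scatter, so this position does respond to the aryl group, though only modestly. Methoxy in place of hydrogen on an aromatic carbon gives a 1.7-fold higher number from compound 1 to compound 3 (0.22 log units; within the scatter), so that change has no readable effect here. Nothing measured on these compounds accounts for either step. Open, as far as these compounds go, is whether an amine or a carboxylic acid on this aryl ring would move growth inhibition further, and in which direction.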